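The source may report more compounds than this note shows. Statements on the series, on what has been measured and on what is new or still open speak of the compounds shown alone.

Measured so far:
compound 1 `CCC(CC)Oc1cc(Oc2cnc(C(=O)N(C)C)nc2)cc(-c2nccc(=O)[nH]2)c1` — in an ADME assay on MDCK-II cells (Canis lupus familiaris) for permeability (on this read-out lower numbers stand for lower permeability and higher numbers for higher permeability), compound 1 gives 17 10^-6 cm/s
compound 2 `CN(C)C(=O)c1ncc(Oc2cc(OC3CCCC3)cc(-c3nccc(=O)[nH]3)c2)cn1` — in this assay compound 2 gives 14 10^-6 cm/s

Among the measured compounds shown here, compound 2 and compound 1 sit within the scatter of each other: the only measured step, a 1.2-fold lower number from compound 1 to compound 2 (0.08 log units; within the scatter), is too small to separate them.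

Compound 3 `C[C@@H](CO)Oc1cc(Oc2cnc(C(=O)N(C)C)nc2)cc(-c2nccc(=O)[nH]2)c1` differs from compound 2 by 1-(hydroxymethyl)ethyl in place of cyclopentyl on an oxygen on an aromatic ring. For the measured compounds named here, that measured step exchanged one ring-free or ring-bearing alkyl for another and brought in no hydrogen-bond donor, so it offers no guide here; no measured step bears on this change. Going by the values given here, with no precedent among the measured compounds, compound 3 is nevertheless expected to give a lower number, a 2.8-fold lower number from compound 2 to compound 3 (0.45 log units; beyond the scatter), estimated at 5 10^-6 cm/s with a range from 2 10^-6 cm/s to 12 10^-6 cm/s.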

Compound 3, apparent permeability: 0.81 10^-6 cm/s
Beside the measured number, compound 3's estimate is 6.2-fold (0.79 log units) above it; measured number outside the range, below it.
By their numbers in this assay, from the lowest: compound 3; then compounds 2 and 1 (each within the scatter of the next).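

At this position, on an oxygen on an aromatic ring, swapping cyclopentyl for pentan-3-yl had left this assay within the scatter, but 1-(hydroxymethyl)ethyl gives a large change: a 17-fold lower number from compound 2 to compound 3 (1.24 log units; beyond the scatter) and a 21-fold lower number from compound 1 to compound 3 (1.32 log units; beyond the scatter). Among the compounds shown here, the position is therefore not indifferent to the group it carries, and the one group that separates here is the only one of the three with a hydrogen-bond donor.

From the compounds shown here alone, whether a methoxy or an amine on the same chain would give a similar fall remains open. Nothing at hand says why the number falls.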